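A few compounds are considered here, and "the series" means these few. Any claim that something is new, unique, unknown or untested is made for them only; others in the source may bear on it.

Measured in a functional assay for antagonist activity, with Cavia porcellus as the target; on this read-out lower numbers stand for stronger inhibition and higher numbers for weaker inhibition:
- compound 1 `CCN(CC)CC#CCCC1(C(O)(c2ccccc2)C2CCCC2)SCCCS1`: 980 nM
- compound 2 `CCN(CC)CC#CCCC1(C(O)(c2ccccc2)C2CCCCC2)SCCCS1`: 1140 nM

Not yet measured: compound 3 `CCN(CC)CC#CCCC1(C(C)(O)c2ccccc2)SCCCS1`.

On these numbers compound 2 stands level with compound 1, as the two values lie within the scatter of each other. The change that leads to compound 3 is methyl in place of cyclohexyl on a saturated chain carbon bound to an aromatic carbon, an oxygen on a saturated carbon and a saturated ring carbon.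

Among the compounds with values here, only one measured step bears on this change: a 1.2-fold higher number from compound 1 to compound 2 (0.07 log units; within the scatter). Within the data shown here, that step exchanges cyclopentyl for cyclohexyl at the same place, and no measured compound lacks a ring there. Its small size therefore gives only weak guidance on this replacement. In this assay, among the measured compounds shown here, a shift to a higher number, beyond the scatter, is expected, but this direction is a judgement that no measured step demonstrates. The expected change is a 4.4-fold higher number from compound 2 to compound 3 (0.64 log units; beyond the scatter). For compound 3 the estimated value is 5000 nM, with an expected range from 1500 nM to 20000 nM.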

Compound 3, antagonist equilibrium constant: 2510 nM
Compound 3: the middle estimate sits 2.0-fold (0.30 log units) above what was measured; low and high end bracket the measured number.
By their numbers in this assay, from the lowest: compounds 1 and 2 (each within the scatter of the next); then compound 3.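

In this assay, the earlier exchange of one ring for another left the values level, so it could not show whether this position responds to its substituent at all; on a saturated chain carbon bound to an aromatic carbon, an oxygen on a saturated carbon and a saturated ring carbon, methyl now gives a 2.2-fold higher number from compound 2 to compound 3 (0.34 log units; beyond the scatter) and a 2.6-fold higher number from compound 1 to compound 3 (0.41 log units; beyond the scatter). Both steps lie beyond the scatter but are modest, so among these three compounds either ring gives stronger inhibition than methyl, yet compound 3 still gives a finite reading of 2510 nM without a ring at this place. Nothing available accounts for this shift.

The compounds shown leave open whether the value changes gradually with the carbon count of the group or depends on the presence of a ring, which ethyl, isopropyl and cyclopropyl at this place would help separate. They also leave open how a group bearing an amine or a hydroxyl would read here, as the three groups compared hold carbon only.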